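A few compounds are considered here, and "the series" means these few. Any claim that something is new, unique, unknown or untested is made for them only; others in the source may bear on it.

Going by the values given here, in a physicochemical assay for lipophilicity, at pH 7.4 (a lower number here means a more polar compound, a higher number a more lipophilic compound), compound 2 `CC(C)CN(Cc1ccccc1C(F)(F)F)S(=O)(=O)c1ccc2c(c1)C(=O)CC(C1CCOCC1)O2` gives 4.32, the lower of the two numbers so far. The other comes from compound 1 `CC(C)CN(c1ccc(C(C)(C)C)cc1)S(=O)(=O)c1ccc2c(c1)C(=O)CC(C1CCOCC1)O2`, which gives 4.97. Compound 3 `CC(C)CN(c1ccc(F)cc1)S(=O)(=O)c1ccc2c(c1)C(=O)CC(C1CCOCC1)O2` has 4-fluorophenyl in place of 2-(trifluoromethyl)benzyl on the sulfonamide nitrogen: 4-fluorophenyl in place of 2-(trifluoromethyl)benzyl on a sulfonamide nitrogen. Among the compounds with values here, only one measured step involves a swap at this nitrogen: a number 0.65 log units lower from compound 1 to compound 2 (beyond the scatter), a modest change beyond the scatter. That step involves a different swap, so it is only a rough guide, and a small further fall in this assay is expected, perhaps within the scatter. The expected change is a number 0.17 log units lower from compound 2 to compound 3 (within the scatter). For compound 3 the estimated value is 4.15, with an expected range of 3.7 to 4.6.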

Compound 3, distribution coefficient: 3.48
For compound 3 the middle estimate is 0.67 log units above the measured one; measured number outside the range, below it.
By their numbers in this assay, from the lowest: compound 3; then compound 2; then compound 1.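

A second kind of swap at the sulfonamide nitrogen also moves the number beyond the scatter in this assay, with a number 0.84 log units lower from compound 2 to compound 3 (beyond the scatter). Keeping the directly attached aromatic ring and changing only its substituent, fluoro in place of tert-butyl on an aromatic carbon, gives a number 1.49 log units lower from compound 1 to compound 3 (beyond the scatter), the largest step so far. Nothing available explains either fall. Still open, as far as these compounds go, is how a group such as an amine or a carboxylic acid on the aromatic ring would read in this assay.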